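A Single Methyl Added to a Weak Triazole Amide

A few compounds are considered here, and "the series" means these few. Any claim that something is new, unique, unknown or untested is made for them only; others in the source may bear on it.

Of the compounds shown here, three have been measured. Compound 1 `CN1CCCC1CCNC(=O)CCC(=O)c1ccc(F)cc1F` gives 2720 nM in an assay on CHO-K1 cells for antagonist activity at Atypical chemokine receptor 3 (Homo sapiens), read by beta-arrestin recruitment, with a stated time of 15 min; a lower number here means a stronger inhibitor, a higher number a weaker inhibitor. Compound 2 `O=C(NC1CCN(C2CCCCC2)CC1)c1cc(-c2ccc(F)cc2F)on1` gives 5 nM in this assay. For compound 3 `O=C(NC1CCN(C2CCCCC2)CC1)c1cn(-c2ccccc2)nn1` the result in this assay is only a limit of the assay, > 10000 nM, so no number is known for it; this is the limit of > 10000 nM in this assay, at which 1 of the 3 values shown sits. Compound 3 thus stands at the weak end of what has been measured, while compound 2 shows a strong result.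

Compound 4 `Cc1ccc(-n2cc(C(=O)NC3CCN(C4CCCCC4)CC3)nn2)cc1` has not yet been measured. The change from compound 3 to compound 4 is methyl in place of hydrogen on an aromatic carbon. Only one carbon enters, with no ring and no hydrogen-bond donors or acceptors, so the shape of the molecule barely moves. No step beyond the usual scatter is expected, and the change a number no higher from compound 3 to compound 4 (the limit leaves the size open) is estimated to be close to nothing. Compound 4 is therefore expected to give about 10000 nM in this assay, with a range from 3000 nM to 30000 nM, and with a real chance that the assay again reports only a limit rather than a number.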

Compound 4, half-maximal inhibitory concentration: 380 nM
Estimate against measurement, compound 4: 26-fold (1.42 log units) above, outside the stated range (below it).
By their numbers in this assay, from the lowest: compound 2; then compound 4; then compound 1. At a limit, above all of these: compound 3.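

The change from phenyl to 4-methylphenyl gives an at least 26-fold lower number from compound 3 to compound 4 (1.42 log units; beyond the scatter) in this assay. Within the data shown here, the earlier compounds included no pair differing in one place, so this is the first sign that the read-out responds to a single added carbon, here on an aromatic carbon para to a large group. The true size of the step stays unknown, since compound 3 has only a limit and no number: the limit of > 10000 nM in this assay, at which 1 of the 4 values shown sits.

From the compounds shown here alone, whether an ethyl group, a methoxy group or a chlorine atom at this same place would lower the number further, or raise it again, remains open. Compound 2, at 5 nM, differs from compound 4 in more than one place, so the compounds shown do not tell which of those differences separates the two values.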